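A few compounds are considered here, and "the series" means these few. Any claim that something is new, unique, unknown or untested is made for them only; others in the source may bear on it.

Measured in a functional assay on NCI-H1299 cells (Homo sapiens) for inhibition, read by CCK-8 assay, with a stated time of 72 h, tested at 1 uM; a lower number here means a weaker effect, a higher number a stronger effect of the compound at the concentration tested:

compound 1 `CN(C)C(=O)c1cc2cnc(Nc3ccc(S(=O)(=O)NCCCN=C=S)cc3)nc2n1C1CCCC1`: 41.3%
compound 2 `CN(C)C(=O)c1cc2cnc(Nc3ccc(C(=O)NCCCCCN=C=S)cc3)nc2n1C1CCCC1`: 50.3%
compound 3 `CN(C)C(=O)c1cc2cnc(Nc3ccc(NC(=O)CCCN=C=S)cc3)nc2n1C1CCCC1`: 39.7%

Compound 3 sits at the low end of the three numbers. Its gap to compound 1 is small, a number 1.6 percentage points lower from compound 1 to compound 3 (within the scatter), and only the gap to compound 2 is beyond the scatter, a number 10.6 percentage points lower from compound 2 to compound 3 (beyond the scatter).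

Compound 4 `CN(C)C(=O)c1cc2cnc(Nc3ccc(NC(=O)CCCCN=C=S)cc3)nc2n1C1CCCC1` differs from compound 3 by a group of 4 heavy atoms (2 carbon, 1 nitrogen, 1 sulfur; no ring) in place of a group of 3 heavy atoms (1 carbon, 1 nitrogen, 1 sulfur; no ring), on a saturated chain carbon, three bonds along the chain from a carbonyl carbon, so the chain between the amide carbonyl and the isothiocyanate grows by one carbon.

Among the compounds with values here, no measured step changes only chain length; the two that change the chain at all also change the linker. In a number 9 percentage points higher from compound 1 to compound 2 (within the scatter) the longer chain goes with a higher number, within the scatter. In a number 10.6 percentage points lower from compound 2 to compound 3 (beyond the scatter) the shorter chain goes with a modestly lower number, beyond the scatter. Both steps therefore point, weakly, to a slightly higher number for the longer chain.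

For compound 4 the expected step is a number 4.3 percentage points higher from compound 3 to compound 4 (within the scatter), within the scatter. The estimate for compound 4 in this assay is 44%, in the range 32% to 56%.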

Compound 4, a percentage reported as inhibition, at one concentration (the size of the read-out at that concentration, not a potency): 58.6%
Compound 4: the middle estimate sits 14.6 percentage points below what was measured, outside the stated range (above it).
By their numbers in this assay, from the lowest: compounds 3, 1, 2 and 4 (each within the scatter of the next, the first and the last beyond it).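

In this assay, within the data shown here, the group of 4 heavy atoms in place of the group of 3 heavy atoms, on a saturated chain carbon, is the first step that changes chain length alone, and it gives a number 18.9 percentage points higher from compound 3 to compound 4 (beyond the scatter); the earlier steps could not separate chain length from the linker. The longer chain also puts this amide series beyond the sulfonamide, with a number 17.3 percentage points higher from compound 1 to compound 4 (beyond the scatter), while the other amide stays close, with a number 8.3 percentage points higher from compound 2 to compound 4 (within the scatter). Nothing available bears on why so small a change in the chain gives a step of this size.

As far as these compounds go, whether a longer chain on the same amide would extend this rise or reverse it remains open. Also open, from the compounds shown here alone, is how much depends on the isothiocyanate itself, which an amine at the chain end would test.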